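The compounds below may be only part of what the source reports. "The series", "measured", "known", "first", "only" and "open" are said of these compounds alone.

Compound 3, `Cc1cccc(-c2ccnc(C(=O)Nc3ccc(Oc4ccnc5[nH]ccc45)c(F)c3)c2)c1`, is measured in a functional assay on MCF7 cells (Homo sapiens) for cytotoxicity, read by MTT assay, with a stated time of 72 h (on this read-out higher numbers stand for weaker inhibition and lower numbers for stronger inhibition), at 9120 nM. Among the three compounds with numbers in this assay it stands second highest; its nearest neighbour is compound 2, `COc1ccc(-c2ccc(C(=O)Nc3ccc(Oc4ccnc5[nH]ccc45)c(F)c3)nc2)cc1`, which gives 10100 nM, and the furthest is compound 1, `Cc1cccc(-c2ccnc(C(=O)Nc3ccc(Oc4ccnc5[nH]ccc45)cc3)c2)c1`, which gives 7470 nM. Both gaps are within the usual scatter, so the three compounds cannot be told apart on these numbers.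

The next compound, compound 4, is `COc1ccc(-c2ccnc(C(=O)Nc3ccc(Oc4ccnc5[nH]ccc45)c(F)c3)c2)cc1`. It differs from compound 3 in one place: 4-methoxyphenyl in place of 3-methylphenyl on an aromatic carbon.

Among the compounds with values here, only one measured step touches a single position, a 1.2-fold higher number from compound 1 to compound 3 (0.09 log units; within the scatter), and it concerns the fluoro group rather than the aryl ring, so it bears on the present change only indirectly. Compound 2 carries a 4-methoxyphenyl group, yet it differs from compound 3 in more than one place, so its value can only be set beside that of compound 3, where the two are within the scatter of each other. Within the data shown here, no direct step for the exchange of 3-methylphenyl for 4-methoxyphenyl exists here. Compound 4 is therefore expected to show a change of a 1.0-fold higher number from compound 3 to compound 4 (0.02 log units; within the scatter), with no step beyond the scatter. Compound 4 is estimated at 9500 nM, within a range from 4500 nM to 20000 nM.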

Compound 4, half-maximal inhibitory concentration: 9110 nM
Estimate against measurement, compound 4: 1.0-fold (0.02 log units) above, and the stated range covers the measured number.
By their numbers in this assay, from the lowest: compounds 1, 4, 3 and 2 (each within the scatter of the next).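

In this assay, within the data shown here, 4-methoxyphenyl in place of 3-methylphenyl gives a 1.0-fold lower number from compound 3 to compound 4 (0.00 log units; within the scatter), the first direct reading of a change at this aryl group, on an aromatic carbon opposite the ring nitrogen; the only earlier single-place step concerned the fluoro group. The entering group brings one oxygen and one hydrogen-bond acceptor that the leaving group lacks, yet compound 3 and compound 4 cannot be told apart, so on this pair the read-out does not separate the two aryl groups. Nothing measured here offers an explanation for this result.

The compounds shown leave open whether an aryl group at this place carrying an amine, a carboxylic acid or a longer chain would give a number beyond the scatter. They also leave open how the substituent and its place on the phenyl ring each count, since the two differ together in this pair, and a 3-methoxyphenyl or 4-methylphenyl group would be needed to separate them.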